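The source may hold more compounds than are shown below. What is called first, only, known or untested is meant among the compounds shown, and "the series" means these compounds.

Going by the values given here, compound 3 `S=c1oc(-c2ccc3c(c2)OCCO3)nn1CN1CCN(c2ccccc2)CC1` is the parent of the three measured members; in a functional assay on BGC-823 cells (Homo sapiens) for antiproliferative activity, read by MTT assay, with a stated time of 48 h (a higher number here means a weaker inhibitor, a lower number a stronger inhibitor), compound 3 returns only the limit > 50000 nM. Compound 1 `Fc1ccccc1N1CCN(Cn2nc(-c3ccc4c(c3)OCCO4)oc2=S)CC1` carries a fluoro on that ring, and compound 1 likewise returns only the limit > 50000 nM. Among the compounds with values here, compound 2 `S=c1oc(-c2ccc3c(c2)OCCO3)nn1CN1CCN(c2cccc(Cl)c2Cl)CC1` is the one member with a number, giving 22600 nM. The measured steps thus read an at least 2.2-fold lower number from compound 1 to compound 2 (0.34 log units; beyond the scatter) and an at least 2.2-fold higher number from compound 2 to compound 3 (0.34 log units; beyond the scatter), while the pair of limits leaves a step that the two limits leave unreadable from compound 1 to compound 3; the shared floor is the limit of > 50000 nM in this assay, at which 2 of the 3 values shown sit.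

The next step is methoxy in place of hydrogen on an aromatic carbon, giving compound 4 `COc1ccccc1N1CCN(Cn2nc(-c3ccc4c(c3)OCCO4)oc2=S)CC1`. Within the data shown here, the only comparable change on the same aromatic carbon is the fluoro of compound 1, which left the value at the limit. A new substituent on that carbon is therefore expected to leave compound 4 at the floor as well, and the step from compound 3 is estimated as a step that the limit leaves unreadable from compound 3 to compound 4. Compound 4 is expected to show 60000 nM in this assay, between 25000 nM and 150000 nM, most likely reported only as a limit.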

Compound 4, half-maximal inhibitory concentration: 19500 nM
The estimate for compound 4 lay 3.1-fold (0.49 log units) above the measured number, and the stated range ends above it.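

In this assay, the aromatic carbon ortho to a large group now proves responsive to substitution: methoxy in place of hydrogen gives an at least 2.5-fold lower number from compound 3 to compound 4 (0.40 log units; beyond the scatter). The outcome depends on the group placed there, since methoxy in place of fluoro gives an at least 2.5-fold lower number from compound 1 to compound 4 (0.40 log units; beyond the scatter), while the fluoro of compound 1 produced no readable step from the parent. A single methoxy on the phenyl also matches the 2,3-dichlorophenyl member, with a 1.2-fold lower number from compound 2 to compound 4 (0.06 log units; within the scatter), so these two are not separated in this assay.

As far as these compounds go, compound 1 and compound 3 are held at a limit of the assay rather than a number, so the true size of the gains over them and the step between them cannot be read: the limit of > 50000 nM in this assay, at which 2 of the 4 values shown sit. It remains open whether an ethoxy, a hydroxyl or an amine on the same carbon would match the methoxy.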